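This account rests on a few compounds, and the source may have more. Where it says the series, first, only, none or still open, it means among the compounds named here.

Compound 1 `Cc1c2c(n3c1CCCN[C@@H](C)[C@H](C)Nc1cc-3ccc1C(N)=O)CC(C)(C)CC2=O` gives 29 nM in a functional assay on HCT-116 cells (Homo sapiens) for antiproliferative activity; on this read-out higher numbers stand for weaker inhibition and lower numbers for stronger inhibition
Compound 2 `Cc1c2c(n3c1CCNC[C@@H](C)[C@H](C)Nc1cc-3ccc1C(N)=O)CC(C)(C)CC2=O` gives 24 nM in this assay
Compound 3 `Cc1c2c(n3c1CCN(C(=O)CN)C[C@@H](C)[C@H](C)Nc1cc-3ccc1C(N)=O)CC(C)(C)CC2=O` gives 216 nM in this assay

Compound 3 carries the highest number of the three, and both other compounds lie lower by more than the scatter. The next compound is compound 4 `CC[C@H](N)C(=O)N1CCc2c(C)c3c(n2-c2ccc(C(N)=O)c(c2)N[C@@H](C)[C@H](C)C1)CC(C)(C)CC3=O` and its change is ethyl in place of hydrogen on a saturated chain carbon bound to an amine nitrogen and a carbonyl carbon with ethyl in place of hydrogen on a saturated chain carbon bound to an amine nitrogen and a carbonyl carbon. For the measured compounds named here, one measured step bears on this, though only indirectly: a 9.0-fold higher number from compound 2 to compound 3 (0.95 log units; beyond the scatter) on placing (aminomethyl)carbonyl in place of hydrogen on an amine nitrogen in a ring. That step shows the acylated amine matters in this assay but does not test any substituent on the chain carbon. Going by the values given here, no measured pair covers aminomethyl to 1-aminopropyl, so no step beyond the scatter is expected, with a slight lean towards a higher number and wide uncertainty. The expected change is a 1.2-fold higher number from compound 3 to compound 4 (0.06 log units; within the scatter) and it remains an estimate. For compound 4 the estimated value is 250 nM with 90 nM to 700 nM as the expected range.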

Compound 4, half-maximal inhibitory concentration: 33 nM
Beside the measured number, compound 4's estimate is 7.6-fold (0.88 log units) above it; measured number below the stated range.
By their numbers in this assay, from the lowest: compounds 2, 1 and 4 (each within the scatter of the next); then compound 3.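

Ethyl in place of hydrogen on the saturated chain carbon bound to an amine nitrogen and a carbonyl carbon gives a 6.5-fold lower number from compound 3 to compound 4 (0.82 log units; beyond the scatter) in this assay, so this carbon is sensitive to substitution. Placing an acyl group on the ring amine nitrogen therefore need not cost activity: (1-aminopropyl)carbonyl gives a 1.4-fold higher number from compound 2 to compound 4 (0.14 log units; within the scatter), against a 9.0-fold higher number from compound 2 to compound 3 (0.95 log units; beyond the scatter) for (aminomethyl)carbonyl, and the outcome depends on the acyl group rather than on acylation alone. No measurement at hand accounts for this difference.

As far as these compounds go, whether methyl, a longer chain or a phenyl ring at this carbon would behave like ethyl remains open, as does the effect of inverting its configuration. Also open, from the compounds shown here alone, is whether the side-chain amine is needed, which a comparison with a butanoyl group on the ring nitrogen would address.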